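From a Pyrrolidine Amide to a Piperidine Amide

This account rests on a few compounds, and the source may have more. Where it says the series, first, only, none or still open, it means among the compounds named here.

Four compounds share one core and differ in the groups attached to it. Compound 1 `CN(C)CCN1CCN(c2nc(-c3cccnc3)nc3c2CN(Cc2ccccc2)CC3)CC1`, compound 2 `CCN(C(C)=O)C1CCN(c2nc(-c3ccccn3)nc3c2CN(Cc2ccc(OC)cc2)CC3)C1` and compound 3 `CCN(C(C)=O)C1CCN(c2nc(-c3ccccn3)nc3c2CN(Cc2ccc(Cl)cc2)CC3)C1` have been measured in an assay on FRT cells with Cystic fibrosis transmembrane conductance regulator variant F508del (Homo sapiens) as the target, read by fluorescence, with a stated time of 25 min; on this read-out higher numbers stand for larger maximal responses and lower numbers for smaller maximal responses. Compound 2 gives 36.9%. Compound 3 gives "not active" (no number reported), so no single number stands for it; compound 1 likewise gives "not active" (no number reported), a further entry without a single number. Within the data shown here, compound 2 and compound 3 carry the same group at the place that changes below and differ elsewhere on the core; no step between them is reported, and all that can be said is that one shows a number and the other does not.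

Compound 4 `CC(=O)NC1CCN(c2nc(-c3ccccn3)nc3c2CN(Cc2ccc(Cl)cc2)CC3)CC1` has not yet been measured. It differs from compound 3 by 4-acetamidopiperidin-1-yl in place of 3-(acetyl(ethyl)amino)pyrrolidin-1-yl on an aromatic carbon. Among the measured compounds shown here, no step of this kind is available, so no size can be taken from the data; with compound 3 showing "not active" (no number reported), a response near the low end of this assay is expected, and any step from compound 3 may well stay within the scatter. Compound 4 is expected to give about 15%, in a range from 0% to 40%.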

Compound 4, largest response reached (Emax), in percent of the reference or control that the assay uses in the Cystic fibrosis transmembrane conductance regulator assay: 65.6%
Estimate against measurement, compound 4: 50.6 percentage points below; measured number above the stated range.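

Among these compounds, compound 3 has no single number in the Cystic fibrosis transmembrane conductance regulator assay so no step from it to compound 4 can be read there. In a physicochemical assay for solubility, read by HPLC, with a stated time of 24 h, at pH 7.4, tested at 250 uM (on this read-out lower numbers stand for lower solubility and higher numbers for higher solubility), compound 3 gives 223000 nM and compound 4 gives 198000 nM (step: a 1.1-fold lower number from compound 3 to compound 4 (0.05 log units; within the scatter)). Why compound 4 shows a response and compound 3 none stays open, and no measurement shown bears on it.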